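Swapping allyl for phenyl on two related amide cores

A few compounds are considered here, and "the series" means these few. Any claim that something is new, unique, unknown or untested is made for them only; others in the source may bear on it.

Compound 1 `C=CCN/C(SC)=C(/C#N)C(=O)Nc1ccc(OCC)cc1`: in a functional assay on PANC-1 cells (Homo sapiens) for cytotoxicity, read by resazurin assay, with a stated time of 48 h (a higher number here means a weaker inhibitor, a lower number a stronger inhibitor), compound 1 gives 21800 nM.
Compound 2 `CCOc1ccc(NC(=O)c2c(N)n[nH]c2Nc2ccccc2)cc1`: in this assay compound 2 gives 21000 nM.
Compound 3 `C=CCNc1[nH]nc(N)c1C(=O)Nc1ccc(OCC)cc1`: in this assay compound 3 gives 30800 nM.

All three measured compounds share the same ethoxyphenyl amide and differ in the part carrying the nitrogen substituent. The values of compound 1, compound 2 and compound 3 lie within the usual scatter of one another, so none of them can be called stronger or weaker than the others. Within the data shown here, the one change that has been measured is phenyl in place of allyl on a nitrogen on an aromatic ring, and it made a 1.5-fold lower number from compound 3 to compound 2 (0.17 log units; within the scatter).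

Compound 4 `CCOc1ccc(NC(=O)/C(C#N)=C(\Nc2ccccc2)SC)cc1` has not yet been measured. It arises from compound 1 by phenyl in place of allyl on an amine nitrogen. Among the measured compounds shown here, this is the same kind of change as the one from compound 3 to compound 2, but not the same: there it sits on a nitrogen on an aromatic ring whose other neighbour is an aromatic carbon, here on an amine nitrogen whose other neighbour is a double-bonded chain carbon. How the core of compound 1 differs from the core of compound 3 is not broken down here.

Because the measured step of this kind gave only a 1.5-fold lower number from compound 3 to compound 2 (0.17 log units; within the scatter), compound 4 is expected to sit close to compound 1, with an estimated step of a 1.2-fold lower number from compound 1 to compound 4 (0.08 log units; within the scatter). The estimate for compound 4 in this assay is 18000 nM, with a likely range from 7000 nM to 50000 nM.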

Compound 4, half-maximal inhibitory concentration: 49300 nM
Compound 4: middle estimate off by 2.7-fold (0.44 log units), on the low side; measured number inside the range.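

Replacing allyl with phenyl on the amine nitrogen of compound 1 gives a 2.3-fold higher number from compound 1 to compound 4 (0.35 log units; beyond the scatter), which in this assay means a modest loss of strength. The same swap on the core of compound 3 produced no change that can be told from scatter, so the two cores do not respond alike, and the gap between the two steps is larger than chance variation would readily explain: the same change on two cores in this assay, a 1.5-fold lower number (0.17 log units; within the scatter) from compound 3 to compound 2 and a 2.3-fold higher number (0.35 log units; beyond the scatter) from compound 1 to compound 4, 3.3-fold (0.52 log units) apart, beyond the scatter of two such steps. Among these compounds, this shows that, in this series, the result of the swap on one core cannot simply be carried over to the other, but with only two pairs it does not show which feature of the cores is responsible, nor whether the pattern would hold for any other change.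

On these data alone, it remains open whether a different group on that nitrogen, such as benzyl or a longer chain, would also separate the two cores, or whether the gap is particular to phenyl and allyl. All four compounds also keep the ethoxyphenyl amide, so it is equally unknown whether the gap would persist with a methoxy group or a carboxylic acid in place of the ethoxy group.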